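The compounds below may be only part of what the source reports. "The series", "measured", "known", "first", "only" and "open" are said of these compounds alone.

Among the compounds with values here, compound 2 `COc1ccc(-c2cc3nn(-c4ccccc4)c(N)c3c(=O)[nH]2)cc1` is one of only two compounds so far measured in an assay on isolated protein for inhibition of serine/threonine-protein kinase Chk2 (Homo sapiens), read by mobility shift assay, tested at 30 uM; a higher number here means more inhibition at the concentration tested (going by the name of the read-out), a lower number less inhibition; in it compound 2 gives -3%. The other, compound 1 `Nc1c2c(=O)[nH]c(-c3ccccc3)cc2nn1-c1ccccc1`, gives -8% in this assay, and the two numbers sit within the scatter of each other, so neither compound can be placed above the other. Compound 3 `CN1CCN(c2ccc(-c3cc4nn(-c5ccccc5)c(N)c4c(=O)[nH]3)cc2)CC1` has not yet been measured. Within the data shown here, it differs from compound 2 in one place: 4-methylpiperazin-1-yl in place of methoxy on an aromatic carbon The single measured step, a number 5 percentage points higher from compound 1 to compound 2 (within the scatter), concerns a change on the same aromatic carbon and did not move the number beyond the scatter. Nothing measured speaks to a 4-methylpiperazin-1-yl group. The step from compound 2 to compound 3 is therefore expected to be small, a number 3 percentage points higher from compound 2 to compound 3 (within the scatter), with no movement beyond the scatter. Compound 3 is estimated at 0%, within a range from -15% to 15%.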

Compound 3, a percentage reported as inhibition, at one concentration (the size of the read-out at that concentration, not a potency): 18%
Beside the measured number, compound 3's estimate is 18 percentage points below it, outside the stated range (above it).
By their numbers in this assay, from the lowest: compounds 1 and 2 (each within the scatter of the next); then compound 3.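

In this assay, swapping methoxy for 4-methylpiperazin-1-yl gives a number 21 percentage points higher from compound 2 to compound 3 (beyond the scatter) and putting the same group in place of hydrogen gives a number 26 percentage points higher from compound 1 to compound 3 (beyond the scatter) on the same aromatic carbon, so this position, para to a large group, can move the number, which the change from hydrogen to methoxy did not show. Among these three compounds, only the group with the non-aromatic ring lifts the reading, and compound 3 at 18% remains a percentage at one concentration rather than a potency. Nothing available explains the rise.

From the compounds shown here alone, whether the step follows the ring or its nitrogen atoms stays open. Morpholin-4-yl or an open-chain dimethylamino group on the same carbon could separate the two.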